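A few compounds are considered here, and "the series" means these few. Any claim that something is new, unique, unknown or untested is made for them only; others in the source may bear on it.

Measured so far in a functional assay on MCF7 cells (Homo sapiens) for inhibition, read by sulforhodamine B assay; a higher number here means a weaker inhibitor, a lower number a stronger inhibitor:
compound 1 `O=C1C(N2CCCCC2)=CC(=O)c2c1nc1n2[C@H]2OC[C@@H](O)[C@H]2OC1`: > 8000 nM
compound 2 `CCOc1ccc(NC2=CC(=O)c3c(nc4n3[C@H]3OC[C@@H](O)[C@H]3OC4)C2=O)cc1`: > 4000 nM

Neither compound has yet given a true half-maximal inhibitory concentration in this assay. Compound 1 gives > 8000 nM, which is a limit and not a number. Compound 2 gives > 4000 nM, which is likewise a limit and not a number. Within the data shown here, the two compounds differ in more than one place, so the data hold no measured step from which to read the effect of a single change.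

The next compound to be tested is compound 3 `O=C1C(Nc2cccc(F)c2)=CC(=O)c2c1nc1n2[C@H]2OC[C@@H](O)[C@H]2OC1`. It keeps the core of compound 2 and carries 3-fluorophenyl in place of 4-ethoxyphenyl on an amine nitrogen. Among the measured compounds shown here, with no measured step to draw on, no clear direction can be argued, and a change beyond the usual scatter is not expected in this assay. The expected step is a step that the limit leaves unreadable from compound 2 to compound 3. The assay may well report only a limit again. Compound 3 is expected at 6000 nM, with an estimated range of 2000 nM to 20000 nM.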

Compound 3, half-maximal inhibitory concentration: > 4000 nM
Compound 3: no number, only a limit (the forecaster's own chance of this, stated with the estimate: 60%); the middle value does not contradict the limit.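

In this assay compound 3 gives > 4000 nM, which is a limit and not a number. Compound 1 and compound 2 also have only limits, so neither the step from compound 2 to compound 3 nor that from compound 1 to compound 3 can be read. The compounds shown leave open what true half-maximal inhibitory concentration, if any, each would reach in this assay.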